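The compounds below may be only part of what the source reports. "The series", "measured", "known", "first", "only" and "open" are said of these compounds alone.

Compound 1 `Nc1cccc(/C=C/c2ccc(O)c(-c3ccccn3)c2)c1` and compound 2 `N/C(=N\O)c1cccc(/C=C/c2ccnc(-c3ccccc3O)c2)c1` share the stilbene-type linker and were run in an assay on isolated protein for inhibition of Amine oxidase [flavin-containing] B (Homo sapiens); on this read-out lower numbers stand for stronger inhibition and higher numbers for weaker inhibition. In this assay compound 1 returns only the assay limit, > 50000 nM. In this assay compound 2 likewise returns only the assay limit, > 50000 nM. For the measured compounds named here, compound 2 thus sits at the limit of > 50000 nM in this assay, at which 2 of the 2 values shown sit, and no measured step is available to set a scale. Compound 3 `N/C(=N\O)c1cccc(/C=C/c2ccnc(-c3cc(F)ccc3O)c2)c1` differs from compound 2 by fluoro in place of hydrogen on an aromatic carbon. With both measured values at the limit, no shift beyond the scatter is expected, and the step is estimated as a step that the limit leaves unreadable from compound 2 to compound 3. In this assay compound 3 is expected near 60000 nM, within 20000 nM to 200000 nM.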

Compound 3, half-maximal inhibitory concentration: > 50000 nM
Compound 3 gave a limit, no number (the forecaster's own chance of this, stated with the estimate: 85%); the middle value does not contradict the limit.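

In this assay, compound 2 and compound 3 both give only a limit, so no step can be read for fluoro in place of hydrogen: the limit of > 50000 nM in this assay, at which 3 of the 3 values shown sit.

The compounds shown leave open which change to the shared core would give a readable value in this assay.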